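This account rests on a few compounds, and the source may have more. Where it says the series, first, only, none or still open, it means among the compounds named here.

Working notes on the series. Compound 1 `CNC(=O)CC1CCc2cc(OC)c(OC)cc21` carries the shared core with an amide whose nitrogen bears a methyl group; in a functional assay on the whole organism (strain Swiss albino) for inhibition, with Mus musculus as the target, in the writhing test, with stated times of 60 min and 15 min, at a dose of 100 mg/kg by the oral route (a lower number here means less inhibition, a higher number more inhibition at the dose given (going by the name of the read-out)), compound 1 gives 21.2%. For the measured compounds named here, compound 2 `CCCCCNC(=O)CC1CCc2cc(OC)c(OC)cc21` differs in one place: the step of a number 50.5 percentage points higher from compound 1 to compound 2 (beyond the scatter) is the single measured step in this set, and in this assay compound 2 gives 71.7%, the highest of the two numbers, with compound 1 as its only neighbour at a distance beyond the scatter.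

Compound 3 `COc1cc2c(cc1OC)C(CC(=O)NCCO)CC2` has not yet been measured in this assay. Its change from compound 2 is hydroxy in place of propyl on a saturated chain carbon, two bonds along the chain from an amide-type nitrogen. Going by the values given here, the measured step bears on this only in part: going from compound 1 to compound 2 the chain on the amide nitrogen was lengthened and inhibition rose by a large amount; going to compound 3 the chain is shortened again, by propyl, while a hydroxy enters, for which no measured pair gives any guidance. The expectation is a downward step in this assay, a number 31.7 percentage points lower from compound 2 to compound 3 (beyond the scatter), smaller than the full reversal of the measured step, since compound 3 still keeps two chain carbons on the nitrogen rather than hydrogen. Compound 3 is therefore estimated at 40% in this assay, with a wide range from 20% to 60%.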

Compound 3, a percentage reported as inhibition, in the whole organism at one dose (the size of the read-out at that dose, not a potency): 29.8%
The estimate for compound 3 lay 10.2 percentage points above the measured number; low and high end bracket the measured number.
By their numbers in this assay, from the lowest: compounds 1 and 3 (each within the scatter of the next); then compound 2.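

The step of a number 41.9 percentage points lower from compound 2 to compound 3 (beyond the scatter) shows that the number reached with the pentyl chain on the amide nitrogen does not hold when 2-hydroxyethyl takes its place. The step of a number 8.6 percentage points higher from compound 1 to compound 3 (within the scatter) places compound 3 level with compound 1 in this assay, so the 2-hydroxyethyl and methyl groups cannot be told apart at this position, and of the three compounds only the pentyl compound stands apart, beyond the scatter from both others. Nothing at hand explains these numbers.

The change from pentyl to 2-hydroxyethyl removes a propyl part and brings in a hydroxy in a single step, so these compounds cannot separate the effect of chain length from that of the hydroxy. Going by these compounds, how a plain ethyl chain, a hexyl chain, or a chain ending in an amine or a carboxylic acid would read in this assay remains open, and with it whether the number keeps rising beyond pentyl.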